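Naphthalen-2-yl in place of 2-chlorophenyl on a triazolopyrimidine hydrazone

The source may report more compounds than this note shows. Statements on the series, on what has been measured and on what is new or still open speak of the compounds shown alone.

Measured so far:
compound 1, `CCCSc1nc(N/N=C/c2ccccc2Cl)c2nnn(Cc3ccccc3)c2n1`, 13800 nM
compound 2, `CCCSc1nc(N/N=C(\C)c2ccccc2O)c2nnn(Cc3ccco3)c2n1`, 29000 nM

The two compounds were tested in a functional assay on MCF7 cells (Homo sapiens) for antiproliferative activity, read by MTT assay, with a stated time of 72 h; a lower number here means a stronger inhibitor, a higher number a weaker inhibitor. Compound 1 gives the lowest of the two numbers; compound 2, its nearest neighbour, gives a number that lies beyond the scatter above it. The pair differs in more than one place, so only the two values themselves can be compared, not any single change.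

Compound 3, `CCCSc1nc(N/N=C/c2ccc3ccccc3c2)c2nnn(Cc3ccccc3)c2n1`, has not yet been measured. It differs from compound 1 in one place: naphthalen-2-yl in place of 2-chlorophenyl on a carbon with a double bond to nitrogen. For the measured compounds named here, no measured pair in this set isolates such a change, so there is no step on which to rest a firm expectation. The step from compound 1 to compound 3 is expected to be small, a 1.3-fold lower number from compound 1 to compound 3 (0.10 log units; within the scatter), likely within the scatter. For compound 3 in this assay the estimate is 11000 nM, with a range from 3500 nM to 35000 nM.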

Compound 3, half-maximal inhibitory concentration: > 64000 nM
Compound 3: a limit, no number; the forecaster's own chance of this, stated with the estimate: 10%; middle value at least 5.8-fold (0.76 log units) away from the limit.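

For the compounds shown here, on the carbon with a double bond to nitrogen, naphthalen-2-yl in place of 2-chlorophenyl gives an at least 4.6-fold higher number from compound 1 to compound 3 (0.66 log units; beyond the scatter), the first change in one place that can be read in this assay. Compound 3 gives no number in this assay, only a limit: the limit of > 64000 nM in this assay, at which 1 of the 3 values shown sits. The step therefore shows that this position does not tolerate every aromatic group, and that going from one six-membered ring to two, with the chlorine gone, costs antiproliferative activity by an amount that is known only as a minimum.

The compounds shown do not separate the loss of the chlorine from the gain of the second ring, which a plain phenyl group at this place would do. They also leave open whether a smaller group, such as a methyl, would keep the activity of compound 1.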